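Carboxy in Place of Hydroxy on the Shared Core

The source may hold more compounds than are shown below. What is called first, only, known or untested is meant among the compounds shown, and "the series" means these compounds.

Compound 3 `Cc1c(C(=O)Nc2c(F)cc(-c3cccc(F)c3)cc2F)nc2ccc(C(F)(F)F)cc2c1O` gives 45.2% in a functional assay on Hep 3B2 cells (Homo sapiens) for antiproliferative activity, read by MTT assay, with a stated time of 24 h, tested at 33.33 ug/mL (on this read-out lower numbers stand for a weaker effect and higher numbers for a stronger effect at the one concentration tested), the highest of the three numbers shown, though compound 2 `Cc1c(C(=O)Nc2c(F)cc(-c3cccc(F)c3)cc2F)nc2ccc(OC(F)(F)F)cc2c1O` with 41.3% and compound 1 `Cc1c(C(=O)Nc2c(F)cc(-c3cccc(F)c3)cc2F)nc2ccc(F)cc2c1O` with 41.2% both sit within the scatter of it: a number 3.9 percentage points higher from compound 2 to compound 3 (within the scatter) and a number 4 percentage points higher from compound 1 to compound 3 (within the scatter). The step of a number 0.1 percentage points higher from compound 1 to compound 2 (within the scatter) is likewise within the scatter. Compound 4 `Cc1c(C(=O)Nc2c(F)cc(-c3cccc(F)c3)cc2F)nc2ccc(C(F)(F)F)cc2c1C(=O)O` differs from compound 3 by carboxy in place of hydroxy on an aromatic carbon. Within the data shown here, none of the measured steps concerns this position; all three exchange groups on another aromatic carbon, and all stay within the scatter. Among the measured compounds shown here, no measured step therefore bears on the change, so no shift beyond the scatter is expected in either direction, and compound 4 is estimated at 45%, between 30% and 60%, a step of a number 0.2 percentage points lower from compound 3 to compound 4 (within the scatter) expected to stay within the scatter.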

Compound 4, a percentage reported as inhibition, at one concentration (the size of the read-out at that concentration, not a potency): 43.3%
The estimate for compound 4 lay 1.7 percentage points above the measured number; the range from low to high includes it.
By their numbers in this assay, from the lowest: compounds 1, 2, 4 and 3 (each within the scatter of the next).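

Among these compounds, at the position opposite the ring nitrogen, which no earlier step touched, carboxy in place of hydroxy gives a number 1.9 percentage points lower from compound 3 to compound 4 (within the scatter) in this assay as the first measured change there. With trifluoromethyl on the shared core, this position therefore accepts the exchange without a shift beyond the scatter. Nothing measured here explains this result.

Going by these compounds, whether an amine or a methoxy group at this position would also stay within the scatter remains open. So does whether carboxy in place of hydroxy gives the same outcome with fluoro or trifluoromethoxy in place of trifluoromethyl.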